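Furan-hydrazone series: removing one fluoro from compound 3

The source may hold more compounds than are shown below. What is called first, only, known or untested is meant among the compounds shown, and "the series" means these compounds.

Measured so far in a functional assay on HL-60 cells (Homo sapiens) for inhibition, read by MTT assay, with a stated time of 48 h, tested at 10 uM; on this read-out higher numbers stand for more inhibition of growth at the one concentration tested and lower numbers for less inhibition of growth:
compound 1 `COc1ccccc1/C=N/NC(=O)c1ccc(-c2ccc(F)cc2F)o1`: 27.4%
compound 2 `O=C(N/N=C/c1ccc(-c2ccc(Cl)cc2)o1)c1ccccc1`: 15.1%
compound 3 `O=C(N/N=C/c1ccc(-c2ccc(F)cc2F)o1)c1ccccc1O`: -9.5%

Compound 3 stands lowest of the three numbers. Compound 2 is its nearest neighbour and sits higher by a margin beyond the scatter; compound 1 lies furthest, higher still and also beyond the scatter. For the measured compounds named here, compound 1 and compound 2 differ from each other in two places, so no single step links them.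

The next compound, compound 4 `O=C(N/N=C/c1ccc(-c2ccc(F)cc2)o1)c1ccccc1O`, differs from compound 3 only in the terminal aryl group: hydrogen in place of fluoro on an aromatic carbon. Going by the values given here, no measured pair shows this change on the shared core, so nothing in the data fixes its size or direction. With no anchor, a step within the scatter is the working expectation, and a number 9.5 percentage points higher from compound 3 to compound 4 (within the scatter) is the estimated shift. Compound 4 is accordingly expected near 0%, within -15% to 15% in this assay.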

Compound 4, percent growth inhibition at one concentration: -2.08%
The estimate for compound 4 lay 2.1 percentage points above the measured number, and the stated range covers the measured number.
By their numbers in this assay, from the lowest: compounds 3 and 4 (each within the scatter of the next); then compound 2; then compound 1.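

In this assay, for the compounds shown here, the change from 2,4-difluorophenyl to 4-fluorophenyl gives the first one-place reading on this core: a number 7.4 percentage points higher from compound 3 to compound 4 (within the scatter). At this place, ortho to a large group, hydrogen in place of fluoro therefore leaves the number within the scatter. No measurement shown bears on a cause for this step.

On these data alone, whether an amine or a trifluoromethyl at this place would give a step beyond the scatter remains open. So does whether the same change reads alike on the core of compound 1.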